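The source may report more compounds than this note shows. Statements on the series, on what has been measured and on what is new or still open speak of the compounds shown alone.

Measured in a physicochemical assay for solubility, at pH 7.4; on this read-out lower numbers stand for lower solubility and higher numbers for higher solubility:
- Compound 1 `Cc1cc(NC(=O)Nc2ccc(C(N)=O)cc2)c2ccccc2n1`: 900 nM
- Compound 2 `Cc1cc(NC(=O)Nc2ccc(N)cc2)c2ccccc2n1`: 18500 nM

Compound 2 stands highest of the two measured numbers. Compound 3 `Cc1cc(NC(=O)Nc2ccc(C(=O)O)cc2)c2ccccc2n1` is the next to read: carboxy in place of amino on an aromatic carbon. For the measured compounds named here, one measured step bears on this place: a 21-fold higher number from compound 1 to compound 2 (1.31 log units; beyond the scatter), a large one, with amino in place of carbamoyl. Going by the values given here, it involves a different pair of groups, and no measured compound carries carboxy, so no step beyond the scatter is expected in this assay. The estimated step is a 1.6-fold higher number from compound 2 to compound 3 (0.21 log units; within the scatter). For compound 3 the expected value is 30000 nM, with an estimated range of 5000 nM to 150000 nM.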

Compound 3, solubility: 9300 nM
Beside the measured number, compound 3's estimate is 3.2-fold (0.51 log units) above it; the measured number falls inside the stated range.
By their numbers in this assay, from the lowest: compound 1; then compounds 3 and 2 (each within the scatter of the next).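

In this assay, for the compounds shown here, the carboxy group is the first replacement at this place that does not separate from amino: a 2.0-fold lower number from compound 2 to compound 3 (0.30 log units; within the scatter). Hydroxy in place of amino on the carbonyl carbon gives a 10-fold higher number from compound 1 to compound 3 (1.01 log units; beyond the scatter), so among these three compounds carbamoyl alone stands apart, and a carbonyl at this place does not by itself go with the low number. Nothing on hand gives a cause for these differences.

Open, from the compounds shown here alone, is where a methyl ester or a sulfonamide at this place would fall. Also open, going by these compounds, is whether the carbamoyl result holds on a different core.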